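The source may report more compounds than this note shows. Statements on the series, on what has been measured and on what is new or still open speak of the compounds shown alone.

Half-lives measured in an ADME assay (liver) for metabolic stability, with Liver microsome (Homo sapiens) as the target, read by LC-MS, using microsomes, tested at 1 uM; on this read-out higher numbers stand for a longer-lived compound and lower numbers for a shorter-lived compound:

- Compound 1 `CCN(CC)CCCN/C(=N\c1ccnc2cc(Cl)ccc12)c1cccnc1`: 0.6 h
- Compound 2 `CCN(CC)CCCCCN/C(C)=N\c1ccnc2cc(Cl)ccc12`: 0.933 h
- Compound 3 `C/C(=N/c1ccnc2cc(Cl)ccc12)NC1CCN(Cc2ccccc2)CC1`: > 1 h, a limit of the assay and not a number

Among the compounds with values here, only two compounds have numeric values. Compound 2 has 0.933 h, and compound 1, within the usual scatter of it, has 0.6 h.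

Compound 4 `C/C(=N/c1ccnc2cc(Cl)ccc12)NCCCN1CCCCC1` differs from compound 2 at one place: piperidin-1-yl in place of 2-(diethylamino)ethyl on a saturated chain carbon, three bonds along the chain from an amine nitrogen. This puts piperidin-1-yl in place of 2-(diethylamino)ethyl on a saturated chain carbon, three bonds along the chain from an amine nitrogen.

Within the data shown here, no measured pair differs at a single place, so this assay offers no direct precedent for this change. No step beyond the scatter is expected, and the estimate stays close to compound 2 at 0.933 h. The expected change is a 1.0-fold lower number from compound 2 to compound 4 (0.02 log units; within the scatter). A limit reading is also possible for compound 4. The estimated half-life of compound 4 is 0.9 h, with an expected range of 0.45 h to 1.8 h.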

Compound 4, half-life: > 1 h
Compound 4 was reported as a limit; the forecaster's own chance of this, stated with the estimate: 30%; at least 1.1-fold (0.04 log units) between middle value and limit.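

In this assay compound 4 gives > 1 h, a limit of the assay and not a number. Piperidin-1-yl in place of 2-(diethylamino)ethyl on a saturated chain carbon, three bonds along the chain from an amine nitrogen, gives an at least 1.0-fold higher number from compound 2 to compound 4 (0.03 log units; that floor lies within the scatter); this is the first single-place step in the series, and it shows that this position accepts the ring with no loss of half-life. The true size of the step stays unread because the reading stops at the limit: the limit of > 1 h in this assay, at which 2 of the 4 values shown sit.

From the compounds shown here alone, how far compound 4 lies past its limit remains open, so the ring's full effect on half-life cannot be stated. Also open, going by these compounds, is how morpholin-4-yl or a dimethylamino group would read at this position, and a single step supports no trend there.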